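Methyl for methoxy: a step from compound 1 toward compound 3

The source may report more compounds than this note shows. Statements on the series, on what has been measured and on what is new or still open speak of the compounds shown alone.

Measured so far:
- compound 1 `COc1ccc(-c2nnc(COc3cnn(C(C)(C)C)c(=O)c3Cl)o2)cc1`: 3.52
- compound 2 `CC(C)(C)n1ncc(OCc2nnc(-c3cc(F)c(F)c(F)c3F)o2)c(Cl)c1=O`: 3.18

In a physicochemical assay for lipophilicity (on this read-out higher numbers stand for higher lipophilicity and lower numbers for lower lipophilicity), compound 1 gives the higher of the two numbers; compound 2 stands lower by a gap beyond the usual scatter. Compound 3 `Cc1ccc(-c2nnc(COc3cnn(C(C)(C)C)c(=O)c3Cl)o2)cc1` has not been measured yet. It differs from compound 1 in one place: methyl in place of methoxy on an aromatic carbon. Among the measured compounds shown here, no measured pair shows this exact change, so the size of the step can only be expected. The step is expected to be upward and modest, as a number 0.48 log units higher from compound 1 to compound 3 (beyond the scatter). On that basis compound 3 is estimated at 4, with a range from 3.6 to 4.4.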

Compound 3, partition coefficient: 3.01
For compound 3 the middle estimate is 0.99 log units above the measured one; the measured number lies below the stated range.
By their numbers in this assay, from the lowest: compounds 3 and 2 (each within the scatter of the next); then compound 1.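

In this assay, the change from 4-methoxyphenyl to 4-methylphenyl gives a number 0.51 log units lower from compound 1 to compound 3 (beyond the scatter) on an otherwise unchanged structure. Among the compounds shown here, this is the first comparison here that differs in one place, and it shows that a change on this aromatic carbon, para to a large group, can shift the number by more than the scatter. Nothing available here explains the direction of the step. From the compounds shown here alone, it remains open where a hydroxyl or an amine at this place would fall, and whether methyl in place of methoxy gives a similar step on another core.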